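Vinyl for nitro on a thiophene-linked phenyl ring

This account rests on a few compounds, and the source may have more. Where it says the series, first, only, none or still open, it means among the compounds named here.

Compound 1: `C/C(=C\c1cccc(-c2ccccc2)c1)C(N)=O`; in a functional assay on T-24 cells (Homo sapiens) for cytotoxicity, read by CCK-8 assay, with a stated time of 24 h (a higher number here means a weaker inhibitor, a lower number a stronger inhibitor), compound 1 gives > 50000 nM.
Compound 2: `C/C(=C\c1cc(-c2ccc([N+](=O)[O-])cc2)cs1)C(N)=O`; in this assay compound 2 gives > 50000 nM.

Both numbers are limits of the assay rather than measured values. Among the measured compounds shown here, the result for compound 2 is a limit, and so it cannot be placed against compound 1 in any order; the two simply share (the limit of > 50000 nM in this assay, at which 2 of the 2 values shown sit), and no step between them can be given a size.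

Compound 3 is `C=Cc1ccc(-c2csc(/C=C(\C)C(N)=O)c2)cc1`. It differs from compound 2 in one place: vinyl in place of nitro on an aromatic carbon. For the measured compounds named here, no step between measured compounds is available to show what such an exchange does in this assay. Since compound 2 sits at the limit of > 50000 nM in this assay, at which 2 of the 2 values shown sit, the step from compound 2 to compound 3 is expected to be small or absent beyond the scatter, giving a step that the limit leaves unreadable from compound 2 to compound 3. Compound 3 is therefore estimated in this assay at 60000 nM, within a range from 15000 nM to 200000 nM, most likely reported again only as a limit.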

Compound 3, half-maximal inhibitory concentration: > 50000 nM
Compound 3 gave a limit, no number (the forecaster's own chance of this, stated with the estimate: 80%); the middle value is on the limit's open side.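

In this assay compound 3 gives > 50000 nM, which is a limit and not a number, so, with compound 2 also a limit, no step can be read between compound 2 and compound 3. All the compounds shown share one limit: the limit of > 50000 nM in this assay, at which 3 of the 3 values shown sit.

The compounds shown leave open whether vinyl in place of nitro changes anything in this assay, and what potency any of them has.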